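This account rests on a few compounds, and the source may have more. Where it says the series, first, only, none or still open, it means among the compounds named here.

In an assay on isolated protein with Bile acid receptor (Homo sapiens) as the target (a higher number here means that more compound is needed for the effect, a lower number that less compound is needed), compound 1 `COC(=O)/C=C/c1cccc(N(Cc2ccc(-c3ccc(OC)cc3)cc2)C(=O)C2CCCCC2)c1` gives 89 nM. Compound 2 `COC(=O)/C=C/c1cccc(N(Cc2ccc(-c3ccc(C(C)(C)C)cc3)cc2)C(=O)C2CCCCC2)c1` carries a tert-butyl where compound 1 carries a methoxy. In this assay compound 2 gives 132 nM; the change between the two is a 1.5-fold higher number from compound 1 to compound 2 (0.17 log units; within the scatter). Compound 3 `COC(=O)/C=C/c1cccc(N(Cc2ccc(Br)cc2)C(=O)C2CCCCC2)c1` is only known as a limit of this assay, > 1000 nM, so no number stands for it. Compound 3 therefore sits at the edge of the measured range, at the limit of > 1000 nM in this assay, at which 1 of the 3 values shown sits. The steps leading there are large: an at least 11-fold higher number from compound 1 to compound 3 (1.05 log units; beyond the scatter), and an at least 7.5-fold higher number from compound 2 to compound 3 (0.87 log units; beyond the scatter).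

Compound 4 `COC(=O)/C=C/c1cccc(N(Cc2ccc(/C=C/C(=O)OCc3ccccc3)cc2)C(=O)C2CCCCC2)c1` is the next member. Its change from compound 3 is 2-(benzyloxycarbonyl)ethenyl in place of bromo on an aromatic carbon. The two steps that bear on it both run the other way: in compound 1 and compound 2 a bromo was exchanged for a substituted phenyl group, and in each case the number dropped beyond the scatter. The entering 2-(benzyloxycarbonyl)ethenyl group also brings a six-membered aromatic ring of carbon only, though at the end of a chain rather than directly attached. The step is therefore expected to lower the number, estimated as an at least 5.5-fold lower number from compound 3 to compound 4 (0.74 log units; beyond the scatter). Compound 4 is expected to give about 180 nM, with a range from 45 nM to 900 nM.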

Compound 4, half-maximal effective concentration: > 1000 nM
Compound 4: only a limit was reported; the forecaster's own chance of this, stated with the estimate: 15%; at least 5.5-fold (0.74 log units) between middle value and limit.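

At this position, on an aromatic carbon para to a large group, a six-membered aromatic ring of carbon only in the entering group is not enough to keep the number at the level of compound 1 and compound 2. Putting 2-(benzyloxycarbonyl)ethenyl in place of the directly attached substituted phenyl group gives an at least 7.5-fold higher number from compound 2 to compound 4 (0.87 log units; beyond the scatter) and an at least 11-fold higher number from compound 1 to compound 4 (1.05 log units; beyond the scatter). Compound 4 is known only as a limit of this assay, > 1000 nM, so the step from compound 3 cannot be read, and the two compounds share the same edge of the range: the limit of > 1000 nM in this assay, at which 2 of the 4 values shown sit.

The compounds shown leave open which part of the entering group matters: the ethenyl link, the ester or the benzyl end. As far as these compounds go, it also remains open whether a phenyl group carrying an amine or a carboxylic acid in place of the methoxy would keep the number in the range of compound 1 and compound 2.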